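The source may report more compounds than this note shows. Statements on the series, on what has been measured and on what is new or still open speak of the compounds shown alone.

Working notes on the series. Compound 1 `CCCC(=O)Nc1ccc(Sc2cccc(OC)c2)cc1`, compound 2 `CCC(=O)Nc1ccc(Nc2cccc(OC)c2)cc1` and compound 3 `CCCC(=O)Nc1ccc(Nc2cccc(OC)c2)cc1` share one anilide core and differ in the linker between the rings and in the acyl chain. In an assay on isolated protein for binding affinity to melatonin receptor type 1B (Homo sapiens) (on this read-out lower numbers stand for stronger inhibition and higher numbers for weaker inhibition), compound 1 gives 0.19 nM, compound 2 gives 1.8 nM and compound 3 gives 0.39 nM. Compound 3 therefore stands second of the three numbers in this assay: compound 1 sits lower by a margin beyond the scatter, compound 2 higher by a margin beyond the scatter.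

Compound 4 `COc1cccc(Nc2ccc(NC(=O)C(C)C)cc2)c1` awaits measurement. It differs from compound 3 by isopropyl in place of propyl on a carbonyl carbon; the two have the same atoms, joined differently. Within the data shown here, the one measured step that touches the acyl chain is a 4.6-fold lower number from compound 2 to compound 3 (0.66 log units; beyond the scatter), where a methyl in place of hydrogen two bonds along the chain lowered the number. Among the measured compounds shown here, no measured pair shows a branched chain, so the effect of isopropyl rests on this single neighbouring step.

A small step upward in this assay is expected, written as a 2.1-fold higher number from compound 3 to compound 4 (0.31 log units; beyond the scatter), since a branched three-carbon chain is not the extension seen in a 4.6-fold lower number from compound 2 to compound 3 (0.66 log units; beyond the scatter). Compound 4 is accordingly estimated at 0.8 nM in this assay, within a range from 0.3 nM to 2.5 nM.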

Compound 4, inhibition constant: 84 nM
Estimate against measurement, compound 4: 110-fold (2.02 log units) below; measured number outside the range, above it.
By their numbers in this assay, from the lowest: compound 1; then compound 3; then compound 2; then compound 4.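

In this assay, the number depends on how the three carbons of the acyl chain are joined and not only on their count: isopropyl in place of propyl on a carbonyl carbon gives a 220-fold higher number from compound 3 to compound 4 (2.33 log units; beyond the scatter), although the two compounds have the same atoms. Added methyl can also move the number either way: a 4.6-fold lower number from compound 2 to compound 3 (0.66 log units; beyond the scatter) follows methyl two bonds along the chain from the carbonyl carbon, whereas a 47-fold higher number from compound 2 to compound 4 (1.67 log units; beyond the scatter) follows methyl on the saturated chain carbon bound to the carbonyl carbon. Nothing available accounts for this reversal.

Still open, on these data alone, is whether a cyclopropyl or tert-butyl group on the same carbonyl carbon tracks compound 4, and whether a longer chain such as butyl tracks compound 3. As far as these compounds go, it is also open whether isopropyl produces a comparable step on the sulfur-linked core of compound 1.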